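The source may report more compounds than this note shows. Statements on the series, on what has been measured and on what is new or still open speak of the compounds shown alone.

Measured in a functional assay on UACC-62 cells (Homo sapiens) for inhibition, read by sulforhodamine B assay, with a stated time of 48 h; on this read-out lower numbers stand for stronger inhibition of growth and higher numbers for weaker inhibition of growth:

- compound 1, `COc1ccc(/C=N/NC(=S)NC(C)(C)[C@H]2CC=C(C)CC2)cc1`: 13300 nM
- compound 2, `CC1=CC[C@H](C(C)(C)NC(=S)N/N=C/c2ccccc2O)CC1`: 2800 nM
- compound 3, `CC1=CC[C@H](C(C)(C)NC(=S)N/N=C/c2ccc(F)cc2)CC1`: only a limit, > 100000 nM

Compound 3 stands at the weak end of the three: its value is the limit of > 100000 nM in this assay, at which 1 of the 3 values shown sits, a limit of this assay and not a number. The two steps that arrive at it both run towards higher numbers, an at least 7.5-fold higher number from compound 1 to compound 3 (0.87 log units; beyond the scatter) and an at least 35-fold higher number from compound 2 to compound 3 (1.55 log units; beyond the scatter), and the step among the other two, a 4.8-fold lower number from compound 1 to compound 2 (0.68 log units; beyond the scatter), puts compound 2 at the low end.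

Compound 4, `CC1=CC[C@H](C(C)(C)NC(=S)N/N=C/c2ccco2)CC1`, is not yet measured. It differs from compound 3 by furan-2-yl in place of 4-fluorophenyl on a carbon with a double bond to nitrogen. Among the compounds with values here, no measured step covers a furan-2-yl, so the size of the change is open; what bears on it is that both steps into compound 3 show the 4-fluorophenyl as the weakest of the three groups tried at this position, and leaving it is therefore expected to give a lower number in this assay rather than a higher one, probably of modest size, with a real chance that the result stays at the limit. For compound 4 the expected value is 30000 nM, within 5000 nM to 150000 nM. This estimate means a step of an at least 3.3-fold lower number from compound 3 to compound 4 (0.52 log units; beyond the scatter), taken as an expectation only.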

Compound 4, concentration for 50% growth inhibition: 10700 nM
For compound 4 the middle estimate is 2.8-fold (0.45 log units) above the measured one; measured number inside the range.
By their numbers in this assay, from the lowest: compound 2; then compounds 4 and 1 (each within the scatter of the next). At a limit, above all of these: compound 3.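

Compound 3 carries a limit and not a number: the limit of > 100000 nM in this assay, at which 1 of the 4 values shown sits. Against that limit, furan-2-yl on a carbon with a double bond to nitrogen gives a measured value in this assay, with an at least 9.3-fold lower number from compound 3 to compound 4 (0.97 log units; beyond the scatter), so a six-membered aromatic ring of carbon only is not required at this position. The furan-2-yl sits level with the 4-methoxyphenyl, with a 1.2-fold lower number from compound 1 to compound 4 (0.09 log units; within the scatter), but does not reach the 2-hydroxyphenyl, with a 3.8-fold higher number from compound 2 to compound 4 (0.58 log units; beyond the scatter).

From the compounds shown here alone, it remains open whether a thiophen-2-yl or a pyridin-2-yl at this position would behave like the furan-2-yl, and whether an amine or a carboxylic acid in place of the hydroxy group of compound 2 would keep its value. The compounds shown also share the rest of the core, so how far these steps hold on a changed core is unknown.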